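Compound 3 and a swapped amide group

This account rests on a few compounds, and the source may have more. Where it says the series, first, only, none or still open, it means among the compounds named here.

Compound 1 `Cc1ccc2[nH]c(C(=O)N[C@H]3CN(S(=O)(=O)c4ccccc4)C[C@@H]3C(=O)NCCN(C)C)cc2c1` gives 2.1
Compound 2 `Cc1ccc2[nH]c(C(=O)N[C@H]3CCN(S(=O)(=O)N4CCCCC4)C[C@@H]3C(=O)NCCN(C)C)cc2c1` gives 2.3
Compound 3 `O=C(N[C@H]1CN(S(=O)(=O)c2ccccc2)C[C@@H]1C(=O)N1C[C@H]2CCNC[C@H]21)c1cc(-c2ccccc2Cl)on1` gives 1.7

In a physicochemical assay for lipophilicity, measured as octanol-water partition, at pH 7.4 (a higher number here means a more lipophilic compound, a lower number a more polar compound), compound 3 stands lowest of the three at 1.7 and its gaps to the other two both lie beyond the usual scatter of repeated measurements. The next compound to be measured is compound 4 `CC(=O)N1CCC[C@H](NC(=O)[C@H]2CN(S(=O)(=O)c3ccccc3)C[C@@H]2NC(=O)c2cc(-c3ccccc3Cl)on2)C1` and it keeps most of compound 3 unchanged. The change sits on a carbonyl carbon and amounts to this a group of 10 heavy atoms (7 carbon, 2 nitrogen, 1 oxygen; one six-membered non-aromatic ring with 1 hetero atom) in place of a group of 8 heavy atoms (6 carbon, 2 nitrogen; one four-membered non-aromatic ring with 1 hetero atom, one six-membered non-aromatic ring with 1 hetero atom), on a carbonyl carbon as the only difference between the two structures.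

Within the data shown here, no measured pair of compounds shows a swap like this one on its own, so any expectation here is loose. Compounds 1 and 2 differ from compound 3 in several places and can only mark out the range of numbers seen so far. A rise beyond the scatter in this assay is nevertheless expected from the nature of the swap, perhaps carrying the number past compound 2 at 2.3 as the top of that range. The expected size is a number 1.00 log units higher from compound 3 to compound 4 (beyond the scatter) as a rough estimate. The estimate for compound 4 is 2.7 and the expected range runs from 2.1 to 3.3 for now.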

Compound 4, distribution coefficient: 3.5
Beside the measured number, compound 4's estimate is 0.80 log units below it, outside the stated range (above it).
By their numbers in this assay, from the lowest: compound 3; then compounds 1 and 2 (each within the scatter of the next); then compound 4.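

On a carbonyl carbon whose other neighbours are a saturated ring carbon, a group of 10 heavy atoms with one six-membered non-aromatic ring replaces a group of 8 heavy atoms with one four-membered and one six-membered non-aromatic ring, and in this assay this gives a number 1.80 log units higher from compound 3 to compound 4 (beyond the scatter). Among these compounds, this is the first change in a single place, and its large size shows that the group on this carbonyl carbon can shift the number strongly, something compounds differing in several places could not isolate. No measurement here explains why the number moved.

The two groups differ at once in their atom counts, ring counts, double bonds outside aromatic rings and defined stereocentres, so this one step cannot show how much of the shift belongs to each difference. As far as these compounds go, how the number would respond to a morpholine ring or a group carrying a carboxylic acid on the same carbonyl carbon remains open, as does whether this swap would give a step of similar size on another core.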